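Pyridin-4-yl to 4-fluorophenyl on the saturated chain

The source may report more compounds than this note shows. Statements on the series, on what has been measured and on what is new or still open speak of the compounds shown alone.

In a functional assay on a cell-free system (plasma, Oryctolagus cuniculus) for inhibition, with stated times of 5 min, 1 min and 6 min (a higher number here means a weaker inhibitor, a lower number a stronger inhibitor), compound 1 `CCOC(=O)c1c(C)nc(-c2cccc(C#N)c2)n1OC` gives 9130 nM and compound 2 `CCOC(=O)COn1c(-c2cccc(C#N)c2)nc(C)c1C(=O)OCC` gives 6800 nM while compound 3 `CCOC(=O)c1c(C)nc(-c2cccc(C#N)c2)n1OCc1ccncc1` gives 6200 nM and so stands level with both within the scatter. Compound 4 `CCOC(=O)c1c(C)nc(-c2cccc(C#N)c2)n1OCc1ccc(F)cc1` differs from compound 3 as follows: 4-fluorophenyl in place of pyridin-4-yl on a saturated chain carbon bound to an oxygen on an aromatic ring with 4-fluorophenyl in place of pyridin-4-yl on a saturated chain carbon bound to an oxygen on an aromatic ring. Changes at that same place were small: a 1.3-fold lower number from compound 1 to compound 2 (0.13 log units; within the scatter) and a 1.5-fold lower number from compound 1 to compound 3 (0.17 log units; within the scatter) and a 1.1-fold lower number from compound 2 to compound 3 (0.04 log units; within the scatter) all lie within the scatter. Going by the values given here, no measured compound carries 4-fluorophenyl. No step beyond the scatter is therefore expected in this assay and the estimated step is a 1.1-fold lower number from compound 3 to compound 4 (0.05 log units; within the scatter) for this change. Compound 4 is expected at 5500 nM with an estimated range from 2200 nM to 13000 nM in this measurement.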

Compound 4, half-maximal inhibitory concentration: 5880 nM
Beside the measured number, compound 4's estimate is 1.1-fold (0.03 log units) below it; the range from low to high includes it.
By their numbers in this assay, from the lowest: compounds 4, 3, 2 and 1 (each within the scatter of the next).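

In this assay pyridin-4-yl giving way to 4-fluorophenyl on a saturated chain carbon bound to an oxygen on an aromatic ring gives a 1.1-fold lower number from compound 3 to compound 4 (0.02 log units; within the scatter) and so removing the hydrogen-bond acceptor counted in pyridin-4-yl leaves the number level. 4-Fluorophenyl in place of ethoxycarbonyl gives a 1.2-fold lower number from compound 2 to compound 4 (0.06 log units; within the scatter) and in place of hydrogen gives a 1.6-fold lower number from compound 1 to compound 4 (0.19 log units; within the scatter) so a carbon-only aromatic ring at this place also stays within the scatter. Nothing available accounts for this flat result.

On these data alone, whether an amine or a carboxylic acid at this place, or a longer chain, would give a step beyond the scatter remains open.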